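The compounds below may be only part of what the source reports. "The series", "measured", "known", "first", "only" and "open" are said of these compounds alone.

Compound 1 `Cc1cccc(N(C)S(=O)(=O)C2CC3OC2C(c2ccc(NC(=O)CCCCCCC(=O)O)cc2)=C3c2ccc(O)cc2)c1` carries a methyl(3-methylphenyl)amino group on a sulfonyl sulfur of the shared core. In an ADME assay on Vero cells (Chlorocebus sabaeus) for antiproliferative activity, read by MTT assay, with a stated time of 72 h (a lower number here means a stronger inhibitor, a higher number a weaker inhibitor), compound 1 gives > 100000 nM, which is a limit of the assay rather than a number. Going by the values given here, compound 2 `CCN(c1ccc(OC)cc1)S(=O)(=O)C1CC2OC1C(c1ccc(NC(=O)CCCCCCC(=O)O)cc1)=C2c1ccc(O)cc1` is its one measured neighbour, with ethyl(4-methoxyphenyl)amino in place of methyl(3-methylphenyl)amino on a sulfonyl sulfur. In this assay compound 2 gives > 100000 nM, again a limit and not a number. The step that the two limits leave unreadable from compound 1 to compound 2 therefore cannot be read, because both values sit at the limit of > 100000 nM in this assay, at which 2 of the 2 values shown sit. Compound 3 `CCN(c1ccccc1Br)S(=O)(=O)C1CC2OC1C(c1ccc(NC(=O)CCCCCCC(=O)O)cc1)=C2c1ccc(O)cc1` has not yet been measured. It differs from compound 1 as follows: (2-bromophenyl)(ethyl)amino in place of methyl(3-methylphenyl)amino on a sulfonyl sulfur. Among the compounds with values here, the only measured step at this position is the unreadable one from compound 1 to compound 2, so no size or direction can be taken from the data. What the two limits do show is that exchanging the group on the sulfonyl sulfur left both compounds at the limit. Compound 3 is therefore expected to give 150000 nM, estimated between 50000 nM and 500000 nM. The expected step from compound 1 is a step that the limit leaves unreadable from compound 1 to compound 3.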

Compound 3, half-maximal inhibitory concentration: > 100000 nM
Compound 3: a limit, no number (the forecaster's own chance of this, stated with the estimate: 80%); the middle value does not contradict the limit.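

In this assay compound 3 gives > 100000 nM, which is a limit and not a number. Going by these compounds alone, no step among compound 1, compound 2 and compound 3 can be read, because all their values sit at one limit: the limit of > 100000 nM in this assay, at which 3 of the 3 values shown sit. The compounds shown leave open whether any group on the sulfonyl sulfur of the shared core gives a readable number in this assay.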